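This account rests on a few compounds, and the source may have more. Where it says the series, first, only, none or still open, it means among the compounds named here.

Measured so far:
compound 1 `CCOC(=O)c1cc(C#Cc2ccc(N)cc2)c2cc(OC)ccc2n1`, 8800 nM;
compound 2 `COc1ccc2nc(-c3c(Cl)cccc3Cl)cc([Se]c3ccccc3)c2c1`, > 150000 nM;
compound 3 `CCOC(=O)c1cc([Se]c2ccc3ccccc3c2)c2cc(OC)ccc2n1`, 32200 nM.

Within the data shown here, in a functional assay on SK-MEL-147 cells (Homo sapiens) for cytotoxicity, read by MTT assay, with a stated time of 24 h (on this read-out higher numbers stand for an effect only at larger amounts of compound and lower numbers for an effect already at smaller amounts), compound 2 shows only a limit of the assay, > 150000 nM, so no number is known for it; it is the one compound sitting at the limit of > 150000 nM in this assay, at which 1 of the 3 values shown sits. Compounds 1 and 3, which both carry the ethoxycarbonyl, give numbers within the range of the assay. Compound 4 `CCOC(=O)c1cc([Se]c2ccccc2)c2cc(OC)ccc2n1` has not been measured in this assay. It differs from compound 2 in one place: ethoxycarbonyl in place of 2,6-dichlorophenyl on an aromatic carbon. Since no measured step between any two of these compounds exists, the expectation rests on compounds 1 and 3 alone: in this assay compound 1 gives 8800 nM and compound 3 gives 32200 nM. Compound 4 is therefore expected to come back with a number rather than a limit, and the estimated step of an at least 3.7-fold lower number from compound 2 to compound 4 (0.57 log units; beyond the scatter) points toward an effect at smaller amounts. Compound 4 is estimated at 40000 nM, likely between 10000 nM and 150000 nM.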

Compound 4, half-maximal effective concentration: 33000 nM
Beside the measured number, compound 4's estimate is 1.2-fold (0.08 log units) above it; measured number inside the range.
By their numbers in this assay, from the lowest: compound 1; then compounds 3 and 4 (each within the scatter of the next). At a limit, above all of these: compound 2.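

Among these compounds, this is the first direct comparison at this position, the aromatic carbon next to the ring nitrogen: in this assay, ethoxycarbonyl in place of 2,6-dichlorophenyl gives an at least 4.5-fold lower number from compound 2 to compound 4 (0.65 log units; beyond the scatter). The value of compound 2 is a limit of the assay, not a number: the limit of > 150000 nM in this assay, at which 1 of the 4 values shown sits. The change therefore brings a measurable number, but only a minimum size is known for the step. On these data alone, how much of this comes from adding ethoxycarbonyl and how much from removing 2,6-dichlorophenyl stays open. A carboxylic acid, an amide or an unsubstituted phenyl on this carbon could help separate the two.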